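A Pyridine Ring Takes the Place of the Chlorophenyl

The source may report more compounds than this note shows. Statements on the series, on what has been measured and on what is new or still open speak of the compounds shown alone.

Among the compounds with values here, compound 2 `COc1ncc(-c2ccc3ncnc(Nc4ccc(OCCO)c(Cl)c4)c3c2)cc1NS(=O)(=O)c1ccc(F)cc1F` gives 7320 nM in a functional assay on HCT-116 cells (Homo sapiens) for antiproliferative activity, read by sulforhodamine B assay, with a stated time of 72 h; on this read-out higher numbers stand for weaker inhibition and lower numbers for stronger inhibition; of the two numbers measured so far it sits alongside compound 1 `COc1ncc(-c2ccc3ncnc(Nc4ccc(OCCO)c(F)c4)c3c2)cc1NS(=O)(=O)c1ccc(F)cc1F`, which gives 9160 nM in this assay, the two within the scatter of each other. Within the data shown here, the only measured step, a 1.3-fold lower number from compound 1 to compound 2 (0.10 log units; within the scatter), came from chloro in place of fluoro on an aromatic carbon. The unmeasured compound 3 `COc1ncc(-c2ccc3ncnc(Nc4ccc(OCCO)nc4)c3c2)cc1NS(=O)(=O)c1ccc(F)cc1F` differs from compound 2 by 6-(2-hydroxyethoxy)pyridin-3-yl in place of 3-chloro-4-(2-hydroxyethoxy)phenyl on a nitrogen on an aromatic ring. Among the measured compounds shown here, no measured step covers an exchange of a carbon-only ring for a ring with one hetero atom; the single step on record speaks only to a small change on that same substituent, which left the number nearly unchanged. Compound 3 is therefore expected to show no step beyond the scatter, a 1.2-fold higher number from compound 2 to compound 3 (0.09 log units; within the scatter), and its number is estimated at 9000 nM with a range of 3500 nM to 25000 nM.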

Compound 3, half-maximal inhibitory concentration: 2340 nM
For compound 3 the middle estimate is 3.8-fold (0.59 log units) above the measured one; the measured number lies below the stated range.
By their numbers in this assay, from the lowest: compound 3; then compounds 2 and 1 (each within the scatter of the next).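

In this assay, the earlier pair had shown only that chloro and fluoro on this substituent lie within the scatter of each other, whereas the full exchange on the nitrogen moves the number beyond the scatter, with a 3.1-fold lower number from compound 2 to compound 3 (0.50 log units; beyond the scatter) and a 3.9-fold lower number from compound 1 to compound 3 (0.59 log units; beyond the scatter) as the two readings of that change. The entering 6-(2-hydroxyethoxy)pyridin-3-yl brings a ring with one hetero atom and also carries no halogen, so these two differences arrive together in a single step and the compounds shown cannot separate them. Nothing available explains the lower number.

The compounds shown leave open whether a chloro or fluoro group on the pyridine ring would keep this gain. They also leave open what an amine or a carboxylic acid at the end of the 2-hydroxyethoxy chain would do to it.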